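Carboxyphenyl in Place of Methoxyphenyl: An Expected Outcome

This account rests on a few compounds, and the source may have more. Where it says the series, first, only, none or still open, it means among the compounds named here.

Of the compounds shown here, three sharing one core have been measured in an assay on CHO cells for inhibition of bone morphogenetic protein 1 (Homo sapiens), with stated times of 10 min and 60 min; on this read-out higher numbers stand for weaker inhibition and lower numbers for stronger inhibition. Compound 1 `CCCCC[C@H](CN(O)C=O)C(=O)NCNC(=O)c1ccc(-c2ccccc2)o1` gives 25 nM, compound 2 `CCCCC[C@H](CN(O)C=O)C(=O)NCNC(=O)c1ccc(-c2cccc(OC)c2)o1` gives 20 nM, and compound 3 `CCCCC[C@@H](C(=O)NCNC(=O)c1cc2cccc(OC)c2o1)[C@@H](CC)N(O)C=O` gives 126 nM. Compound 2 and compound 1 cannot be told apart on this read-out, since a 1.3-fold lower number from compound 1 to compound 2 (0.10 log units; within the scatter); compound 3, whose structure differs in several places at once, gives a clearly larger number than compound 2.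

Compound 4 `CCCCC[C@H](CN(O)C=O)C(=O)NCNC(=O)c1ccc(-c2ccc(C(=O)O)cc2)o1` has not yet been measured. It differs from compound 2 in a single place: 4-carboxyphenyl in place of 3-methoxyphenyl on an aromatic carbon. Within the data shown here, only one measured step touches the same pendant ring, the one from compound 1 to compound 2, and it stayed within the scatter. Among the measured compounds shown here, no measured compound carries a carboxylic acid, so nothing observed speaks to this change directly. The expectation is therefore a small step, a 2.0-fold higher number from compound 2 to compound 4 (0.30 log units; within the scatter), with a wide allowance for surprise. Compound 4 is estimated at 40 nM, with a plausible range from 10 nM to 160 nM.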

Compound 4, half-maximal inhibitory concentration: 1 nM
Compound 4: the middle estimate sits 40-fold (1.60 log units) above what was measured; measured number outside the range, below it.
By their numbers in this assay, from the lowest: compound 4; then compounds 2 and 1 (each within the scatter of the next); then compound 3.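

In this assay the phenyl ring on the aromatic carbon next to the ring oxygen proves far from indifferent to what it carries: 4-carboxyphenyl in place of 3-methoxyphenyl gives a 20-fold lower number from compound 2 to compound 4 (1.30 log units; beyond the scatter), and carboxy in place of hydrogen gives a 25-fold lower number from compound 1 to compound 4 (1.40 log units; beyond the scatter). Among these compounds, the only earlier change on this ring, methoxy for hydrogen, stayed within the scatter, so a small step there said little about how a different group would behave on the same ring. Nothing available explains why the carboxy group brings such a large gain.

Going by these compounds, whether the 4-carboxyphenyl arrangement is needed stays open, and 3-carboxyphenyl or 4-methoxyphenyl would help separate the group from its place on the ring. Also open, on these data alone, is whether the free carboxylic acid is required, or whether a methyl ester, a primary amide or a tetrazole would give a similar number.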